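A few compounds are considered here, and "the series" means these few. Any claim that something is new, unique, unknown or untested is made for them only; others in the source may bear on it.

Compound 1, `COc1ccc(/C=C2\CCCc3ccccc3C2=O)cc1`, is a benzylidene ketone that in a functional assay on P388 cells (Mus musculus) for inhibition (on this read-out higher numbers stand for weaker inhibition and lower numbers for stronger inhibition), gives 1600 nM. Its closest relative in the set is compound 2, `CN(C)c1ccc(/C=C2\CCCc3ccccc3C2=O)cc1`, which carries dimethylamino in place of methoxy on an aromatic carbon and in this assay gives 1900 nM. The step between them is a 1.2-fold higher number from compound 1 to compound 2 (0.07 log units; within the scatter), so the two values cannot be ordered against each other.

Compound 3, `COc1ccc(/C=C2\CCCCCC2=O)cc1`, keeps the methoxy-substituted benzylidene group but has a different core; how the two cores differ is not broken down here. In this assay compound 3 reaches only > 50000 nM, which is a limit of the assay and not a number; the evidence is the limit of > 50000 nM in this assay, at which 1 of the 3 values shown sits.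

The unmeasured compound 4, `CN(C)c1ccc(/C=C2\CCCCCC2=O)cc1`, is to compound 3 what compound 2 is to compound 1: it carries dimethylamino in place of methoxy on an aromatic carbon. The surroundings of the place are described a little differently, para to a group of 9 heavy atoms here against para to a large group there, so this is the same kind of change rather than the same change.

Compound 4 is expected to show a step that the limit leaves unreadable from compound 3 to compound 4. That expectation rests on the measured step of a 1.2-fold higher number from compound 1 to compound 2 (0.07 log units; within the scatter) in this assay, which lay within the scatter. Since compound 3 itself reached only a limit in this assay, compound 4 is estimated to fall near 60000 nM, most likely between 20000 nM and 200000 nM, with a good chance that only a limit is reported again.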

Compound 4, half-maximal inhibitory concentration: 18800 nM
Beside the measured number, compound 4's estimate is 3.2-fold (0.50 log units) above it, and the stated range ends above it.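

On the core of compound 3, dimethylamino in place of methoxy gives an at least 2.6-fold lower number from compound 3 to compound 4 (0.42 log units; beyond the scatter) in this assay. The same change left no readable difference on the core of compound 1, so its result did not carry over unchanged from one core to the other: the same change on two cores in this assay, a 1.2-fold higher number (0.07 log units; within the scatter) from compound 1 to compound 2 and an at least 2.6-fold lower number (0.42 log units; beyond the scatter) from compound 3 to compound 4, at least 3.1-fold (0.49 log units) apart, beyond the scatter of two such steps This does not show how large the step on the core of compound 3 really is, nor why the two cores part ways, and two pairs give no rule for any further core, since compound 3 stands only at a limit of the assay: the limit of > 50000 nM in this assay, at which 1 of the 4 values shown sits.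

The compounds shown leave open whether the gap between the two cores is particular to methoxy and dimethylamino or also appears with other groups on that aromatic carbon, such as a hydroxyl, a fluorine or a nitrile. They also leave open how a larger amine, such as a pyrrolidine or a morpholine, would behave there on either core, and so whether the step seen on the core of compound 3 extends beyond dimethylamino.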